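A Hydroxylated Cyclohexyl Replaces the Oxanylmethyl Chain

The compounds below may be only part of what the source reports. "The series", "measured", "known", "first", "only" and "open" are said of these compounds alone.

Three compounds sharing one core differ only in the group on the nitrogen bound to the aromatic ring. In an assay on isolated protein for inhibition of protein kinase C theta type (Homo sapiens), read by TR-FRET, with a stated time of 2 h (a higher number here means a weaker inhibitor, a lower number a stronger inhibitor), compound 1 `N#Cc1cnc(NCc2cnccc2C(F)(F)F)cc1NC[C@H]1C[C@H](O)C1` gives 700 nM, compound 2 `N#Cc1cnc(NCc2cnccc2C(F)(F)F)cc1N[C@H]1CC[C@@H](O)CC1` gives 100 nM, and compound 3 `N#Cc1cnc(NCc2cnccc2C(F)(F)F)cc1NCC1CCOCC1` gives 400 nM, which places compound 3 second highest of the three, near compound 1 and furthest from compound 2. Compound 4 `CC1(C)C[C@@H](Nc2cc(NCc3cnccc3C(F)(F)F)ncc2C#N)CC[C@@H]1O` carries 4-hydroxy-3,3-dimethylcyclohexyl in place of (oxan-4-yl)methyl on a nitrogen on an aromatic ring. The step of a 4.0-fold higher number from compound 2 to compound 3 (0.60 log units; beyond the scatter) is the closest guide, since it runs the opposite way between 4-hydroxycyclohexyl and (oxan-4-yl)methyl, and a 7.0-fold lower number from compound 1 to compound 2 (0.85 log units; beyond the scatter) also favoured 4-hydroxycyclohexyl. A lower number is therefore expected for compound 4, by about a 3.6-fold lower number from compound 3 to compound 4 (0.56 log units; beyond the scatter). Compound 4 is estimated at 110 nM, within 40 nM to 300 nM.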

Compound 4, half-maximal inhibitory concentration: 120 nM
Compound 4: the middle estimate sits 1.1-fold (0.04 log units) below what was measured; the range from low to high includes it.
By their numbers in this assay, from the lowest: compounds 2 and 4 (each within the scatter of the next); then compounds 3 and 1 (each within the scatter of the next).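

In this assay, the 3,3-dimethyl substitution costs the 4-hydroxycyclohexyl group nothing that can be detected at this nitrogen, with a 1.2-fold higher number from compound 2 to compound 4 (0.08 log units; within the scatter). The advantage over the chain-linked groups also persists in the larger 4-hydroxy-3,3-dimethylcyclohexyl group, with a 3.3-fold lower number from compound 3 to compound 4 (0.52 log units; beyond the scatter) and a 5.8-fold lower number from compound 1 to compound 4 (0.77 log units; beyond the scatter). The hydroxylated cyclohexyl result therefore now rests on both compound 2 and compound 4.

No measurement shown here explains these steps. As far as these compounds go, it remains open whether the hydroxyl itself is needed, or whether an amine or a methoxy group at that ring position would serve equally well.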